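The compounds below may be only part of what the source reports. "The series", "measured", "known", "first", "only" and "open" are said of these compounds alone.

Working notes on the series. Compound 1 `CNC(=O)Nc1cc(Oc2cncc(OC)c2)c(C2=CCCOC2)cn1` was run in an ADME assay on the whole organism (Rattus norvegicus) for pharmacokinetics, at a dose of 0.5 mg/kg by the intravenous route (a lower number here means slower removal, a higher number faster removal of the compound), and gives 38.3 mL/min/kg, the higher of the two numbers in hand. Compound 2 `CNC(=O)Nc1cc(Oc2cncc(C)c2)c([C@H]2C[C@@H](O)C2)cn1` gives 21.7 mL/min/kg in this assay; the two values lie within the scatter of each other, so no order between them is claimed. Compound 3 `CNC(=O)Nc1cc(Oc2cncc(OC)c2)c(C2CCOCC2)cn1` is not yet measured. It differs from compound 1 by a group of 6 heavy atoms (5 carbon, 1 oxygen; one six-membered non-aromatic ring with 1 hetero atom) in place of a group of 6 heavy atoms (5 carbon, 1 oxygen; one six-membered non-aromatic ring with 1 hetero atom), on an aromatic carbon. Going by the values given here, no measured step informs this change, so the step from compound 1 is expected to stay within the scatter: a 1.2-fold lower number from compound 1 to compound 3 (0.08 log units; within the scatter). Compound 3 is estimated at 32 mL/min/kg, with a range from 16 mL/min/kg to 64 mL/min/kg.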

Compound 3, clearance: 46.7 mL/min/kg
For compound 3 the middle estimate is 1.5-fold (0.16 log units) below the measured one; the measured number falls inside the stated range.
By their numbers in this assay, from the lowest: compounds 2, 1 and 3 (each within the scatter of the next, the first and the last beyond it).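

In this assay, oxan-4-yl at the aromatic carbon para to the (methylcarbamoyl)amino group, taking the place of the ring with the double bond, gives a 1.2-fold higher number from compound 1 to compound 3 (0.09 log units; within the scatter) and so stays within the scatter. At this position, on the core of compound 1, the double bond outside aromatic rings is therefore not needed to keep the read-out where it stands. Nothing at hand bears on a cause for this step.

Still open, as far as these compounds go, is whether an amine or a carboxylic acid on the oxan-4-yl ring, or a longer open chain in its place, would move the number beyond the scatter of compound 3.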